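Aminotriazole thioethers: ketone to anilide on the shared core

This account rests on a few compounds, and the source may have more. Where it says the series, first, only, none or still open, it means among the compounds named here.

Measured compounds:
compound 1 `COc1cc(-c2nnc(SCC(=O)c3ccccc3)n2N)cc(OC)c1OC`: > 100000 nM
compound 2 `COc1ccc(C(=O)CSc2nnc(-c3cc(OC)c(OC)c(OC)c3)n2N)cc1`: 17400 nM

Compound 1 `COc1cc(-c2nnc(SCC(=O)c3ccccc3)n2N)cc(OC)c1OC` stands at a limit of a functional assay on HeLa cells (Homo sapiens) for antiproliferative activity, read by MTT assay, with a stated time of 48 h (a higher number here means a weaker inhibitor, a lower number a stronger inhibitor), rather than at a number, with > 100000 nM; (the limit of > 100000 nM in this assay, at which 1 of the 2 values shown sits). Going by the values given here, compound 2 `COc1ccc(C(=O)CSc2nnc(-c3cc(OC)c(OC)c(OC)c3)n2N)cc1` gives 17400 nM in this assay, and the only measured step, an at least 5.7-fold lower number from compound 1 to compound 2 (0.75 log units; beyond the scatter), concerns methoxy in place of hydrogen on an aromatic carbon.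

Compound 3 `COc1cc(-c2nnc(SCC(=O)Nc3ccccc3)n2N)cc(OC)c1OC` differs from compound 1 by anilino in place of phenyl on a carbonyl carbon. Among the compounds with values here, no measured step covers this change, so no direction beyond the scatter can be drawn from the numbers; compound 1 offers only its limit as anchor. Compound 3 is therefore expected to remain weak, with an estimated 80000 nM (range 20000 nM to 300000 nM), and the step of an at least 1.2-fold lower number from compound 1 to compound 3 (0.09 log units; that floor lies within the scatter) is taken as an expectation only.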

Compound 3, half-maximal inhibitory concentration: 8280 nM
Compound 3: middle estimate off by 9.7-fold (0.99 log units), on the high side; the whole stated range lies above it.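

On the carbonyl carbon, anilino in place of phenyl gives an at least 12-fold lower number from compound 1 to compound 3 (1.08 log units; beyond the scatter), so in this assay the change from ketone to anilide on the shared core matters on its own. Anilino, with no substituent on its ring, also compares well with the 4-methoxyphenyl ketone, giving a 2.1-fold lower number from compound 2 to compound 3 (0.32 log units; beyond the scatter). The size of the first step remains open-ended, as compound 1 stands at a limit and not at a number: the limit of > 100000 nM in this assay, at which 1 of the 3 values shown sits.

On these data alone, whether 4-methoxyanilino adds to the anilide gain stays open. So does the outcome of benzylamino or N-methylanilino on the same carbonyl carbon.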